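The source may hold more compounds than are shown below. What is called first, only, known or untested is meant among the compounds shown, and "the series" means these compounds.

Measured so far:
compound 1, `Nc1ccccc1NC(=O)c1ccc(CSC(=S)N2CCN(C(c3ccccc3)c3ccccc3)CC2)cc1`: 8%
compound 2, `Nc1ccccc1NC(=O)c1ccc(CSC(=S)N2CCc3ccccc32)cc1`: 38%

Both were tested in a functional assay on HeLa cells (Homo sapiens) for antiproliferative activity, read by CCK-8 assay, with a stated time of 72 h, tested at 2 uM; a lower number here means a weaker effect, a higher number a stronger effect of the compound at the concentration tested. Compound 1 gives 8%, the lowest of the two numbers, while compound 2 gives 38%, a gap that lies beyond the usual scatter. Compound 3, `Nc1ccccc1NC(=O)c1ccc(CSC(=S)N2CCN(Cc3ccccc3)CC2)cc1`, has not yet been measured in this assay. It differs from compound 1 in a single place: hydrogen in place of phenyl on a saturated chain carbon bound to an amine nitrogen in a ring and an aromatic carbon. The shared core of compound 1 is kept unchanged. Among the measured compounds shown here, no measured pair shows the effect of such a change, so there is no step to lean on. Because compound 1 already gives only 8%, a small change is expected in this assay, either upward or none beyond the scatter. For compound 3 the expected value is 12%, with a range from 0% to 30%. The step of a number 4 percentage points higher from compound 1 to compound 3 (within the scatter) is expected to be small.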

Compound 3, a percentage reported as inhibition, at one concentration (the size of the read-out at that concentration, not a potency): 20.6%
For compound 3 the middle estimate is 8.6 percentage points below the measured one, and the stated range covers the measured number.
By their numbers in this assay, from the lowest: compound 1; then compound 3; then compound 2.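

In this assay, hydrogen in place of phenyl on a saturated chain carbon bound to an amine nitrogen in a ring and an aromatic carbon gives a number 12.6 percentage points higher from compound 1 to compound 3 (beyond the scatter) in the read-out. This shows that the group on this carbon matters in this assay, and that the compound keeps its effect without the phenyl that leaves, with the number rising, though only modestly. Nothing available here explains why the number moves with this change.

As far as these compounds go, it remains open whether a different group on this carbon, such as a methyl or a hydroxyl, would lift the number further or lower it. From the compounds shown here alone, it is also open how a longer chain between the ring nitrogen and the remaining phenyl would behave, and a reading at one concentration says nothing about potency.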